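This account rests on a few compounds, and the source may have more. Where it says the series, first, only, none or still open, it means among the compounds named here.

Working notes on the series. Among the compounds with values here, compound 1 `CCOC(=O)C1=C(C)N(c2cccc(Cl)c2)C(C)=C(C(=O)OCC)C1c1cn(-c2ccccc2)nc1-c1ccccc1` is the only member with a number in an ADME assay on Vero cells (Chlorocebus sabaeus) for cytotoxicity; a higher number here means a weaker inhibitor, a lower number a stronger inhibitor; in this assay compound 1 gives 7.08 ug/mL. Compound 2 `CC(=O)C1=C(C)N(c2ccccc2)C(C)=C(C(C)=O)C1c1cn(-c2ccccc2)nc1-c1ccccc1` carries the same diaryl pyrazole unit on the shared core but with methyl ketones in place of the esters and an unsubstituted phenyl on the ring nitrogen; in this assay the record for compound 2 reads "not determined" (no result reported), so compound 2 stands on no single number, and nothing can be said of how it compares with compound 1. Compound 3 `CC(=O)C1=C(C)N(c2cccc(C)c2)C(C)=C(C(C)=O)C1c1cn(-c2ccccc2)nc1-c1ccccc1` is the next member and remains to be measured in this assay. The change from compound 2 to compound 3 is methyl in place of hydrogen on an aromatic carbon. With no measured pair of this kind in hand, the step in this assay from compound 2 to compound 3 is expected to be small, in no fixed direction, and most likely within the usual scatter of the measurement. On that basis compound 3 is estimated to give about 8 ug/mL in this assay, with a range from 3 ug/mL to 25 ug/mL.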

Compound 3, half-maximal inhibitory concentration: > 10 ug/mL
Compound 3 was reported as a limit; the forecaster's own chance of this, stated with the estimate: 20%; middle value at least 1.2-fold (0.09 log units) away from the limit.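

In this assay compound 3 is reported only as a limit, not a number: the limit of > 10 ug/mL in this assay, at which 1 of the 3 values shown sits.

Within the data shown here, with no single number for compound 2, no step from compound 2 to compound 3 can be read. The compounds shown leave open whether methyl in place of hydrogen on the aromatic carbon changes the reading in this assay at all, and in which direction.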